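Amine nitrogen substitution on the shared core: compound 4

A few compounds are considered here, and "the series" means these few. Any claim that something is new, unique, unknown or untested is made for them only; others in the source may bear on it.

Measured so far in an assay on HEK293 cells for displacement of a labelled ligand from Melanocortin receptor 4 (Homo sapiens); on this read-out higher numbers stand for weaker inhibition and lower numbers for stronger inhibition:
Compound 1 `CCN[C@H](c1cc(C(F)(F)F)ccc1N1CCN(C(=O)CCc2ccc(Cl)cc2Cl)CC1)C(C)CC` gives 92 nM.
Compound 2 `CCC(C)CN[C@H](c1cc(C(F)(F)F)ccc1N1CCN(C(=O)CCc2ccc(Cl)cc2Cl)CC1)C(C)CC` gives 2800 nM.
Compound 3 `CCC(C)[C@H](NCc1ccccc1F)c1cc(C(F)(F)F)ccc1N1CCN(C(=O)CCc2ccc(Cl)cc2Cl)CC1` reaches only the limit of this assay, > 10000 nM.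

Compound 3 thus stands at the weak end of the three numbers, on the limit line (the limit of > 10000 nM in this assay, at which 1 of the 3 values shown sits), and no number is known for it. The measured steps all change the group on the saturated chain carbon bound to the amine nitrogen: a 30-fold higher number from compound 1 to compound 2 (1.48 log units; beyond the scatter), an at least 100-fold higher number from compound 1 to compound 3 (2.03 log units; beyond the scatter), and an at least 3.5-fold higher number from compound 2 to compound 3 (0.55 log units; beyond the scatter). Each enlargement there weakened binding.

Compound 4 `CCC(C)[C@H](NC(C)=O)c1cc(C(F)(F)F)ccc1N1CCN(C(=O)CCc2ccc(Cl)cc2Cl)CC1` differs from compound 3 elsewhere: acetyl in place of 2-fluorobenzyl on an amine nitrogen. For the measured compounds named here, no measured step touches the amine nitrogen itself, so the three steps above bear on compound 4 only indirectly; they show the series reaching the limit once the chain carbon carries 2-fluorophenyl, which compound 4 keeps. The expectation is therefore that compound 4 stays around the limit, with no step beyond the scatter, a step that the limit leaves unreadable from compound 3 to compound 4. Compound 4 is estimated at 15000 nM in this assay, between 4000 nM and 60000 nM, most likely reported again only as a limit.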

Compound 4, inhibition constant: 360 nM
Compound 4: middle estimate off by 42-fold (1.62 log units), on the high side; the measured number lies below the stated range.
By their numbers in this assay, from the lowest: compound 1; then compound 4; then compound 2. At a limit, above all of these: compound 3.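

In this assay the group on the amine nitrogen proves able to bring the series back off the limit: acetyl in place of 2-fluorobenzyl gives an at least 27-fold lower number from compound 3 to compound 4 (1.44 log units; beyond the scatter), so a carbonyl directly on this nitrogen is tolerated, which the three alkyl-type groups could not show. Acetyl also improves on 2-methylbutyl, with a 7.8-fold lower number from compound 2 to compound 4 (0.89 log units; beyond the scatter), while ethyl stays ahead of it, with a 3.9-fold higher number from compound 1 to compound 4 (0.59 log units; beyond the scatter), so the four compounds order by nitrogen group as ethyl, acetyl, 2-methylbutyl and 2-fluorobenzyl, and none of them goes against a rise in the number as the group grows. Compound 3 stands on a limit, so its step is a bound and not a measured distance: the limit of > 10000 nM in this assay, at which 1 of the 4 values shown sits.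

The compounds shown leave open whether the gain with acetyl comes from the carbonyl or only from the smaller group, a question that a propyl and propanoyl pair on this nitrogen, or 2-fluorobenzoyl set against 2-fluorobenzyl, would separate. Also open, going by these compounds, is how the free primary amine or a single methyl on the nitrogen would compare with ethyl.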